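Adding a Fluorine Beside a Ring Chlorine

A few compounds are considered here, and "the series" means these few. Any claim that something is new, unique, unknown or untested is made for them only; others in the source may bear on it.

Of the compounds shown here, three have been tested so far in a functional assay on MDA-MB-231 cells (Homo sapiens) for cytotoxicity, read by MTT assay, with a stated time of 72 h; a lower number here means a stronger inhibitor, a higher number a weaker inhibitor. Compound 1 `Fc1ccc(Nc2cc(Nc3ccc(Oc4ccncc4-c4cccnc4)c(F)c3)ncn2)cc1F` gives 6770 nM in this assay. For compound 2 `Fc1cc(Nc2cc(Nc3ccc(Cl)cc3)ncn2)ccc1Oc1ccncc1-c1cccnc1` the entry in this assay reads "not determined" (no result reported), so no number is available for it. Compound 3 `Cn1c(=O)c(C(=O)Nc2ccc(Oc3ccncc3-c3cccnc3)c(F)c2)nn(-c2ccc(Cl)cc2)c1=O` gives 3220 nM in this assay, the lower of the two numbers available, and the gap between compound 3 and compound 1 lies beyond the usual scatter of repeated measurements.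

Compound 4 `Cn1c(=O)c(C(=O)Nc2ccc(Oc3ccncc3-c3cccnc3)c(F)c2)nn(-c2ccc(F)c(Cl)c2)c1=O` has not yet been measured. It differs from compound 3 in one place: 3-chloro-4-fluorophenyl in place of 4-chlorophenyl on an aromatic nitrogen. No pair of measured compounds shows what such a change does in this assay, so no shown step can be used as a guide.

The step from compound 3 to compound 4 is expected to be small, a 1.1-fold lower number from compound 3 to compound 4 (0.03 log units; within the scatter), and is not expected to reach beyond the scatter in either direction. For compound 4 the expected value in this assay is 3000 nM, with a likely range from 1300 nM to 7000 nM.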

Compound 4, half-maximal inhibitory concentration: 11300 nM
Compound 4: middle estimate off by 3.8-fold (0.58 log units), on the low side, and the stated range ends below it.
By their numbers in this assay, from the lowest: compound 3; then compounds 1 and 4 (each within the scatter of the next).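

In this assay the phenyl group on the aromatic nitrogen of the shared core proves sensitive to a small edit: 3-chloro-4-fluorophenyl in place of 4-chlorophenyl gives a 3.5-fold higher number from compound 3 to compound 4 (0.55 log units; beyond the scatter) and so a weaker inhibitor, by a step beyond the usual scatter. Among these compounds, both groups are a six-membered aromatic ring of carbon only, with no hydrogen-bond donors or acceptors and no net charge, so this place responds to a change that leaves those counts untouched, something the earlier compounds could not show. No measurement on hand bears on the reason for this step.

This single step changes two things at once, and a 3-chlorophenyl or a 4-fluorophenyl group at this place would be needed to tell whether the rise goes with the chlorine in its new place or with the added fluorine. Also open, on these data alone, is how this place responds to groups of another kind on the phenyl ring, such as a methoxy group, an amine or a carboxylic acid.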